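Cyclohexyl amide series: removing one aryl methoxy group

This account rests on a few compounds, and the source may have more. Where it says the series, first, only, none or still open, it means among the compounds named here.

Of the compounds shown here, two have so far been measured in a functional assay on QGY7701 cells (Homo sapiens) for cytotoxicity, read by MTT assay, with a stated time of 24 h; a higher number here means a weaker inhibitor, a lower number a stronger inhibitor. Compound 1 `C=CC1=C(C(=O)Nc2ccc(OCC)cc2)C(c2ccc(OC)cc2)OC1` gives only a limit there: in this assay compound 1 reaches > 100000 nM, which is a limit of the assay and not a number. Among the compounds with values here, compound 2 `C=CC1=C(C(=O)NC2CCCCC2)C(c2ccc(OC)c(OC)c2)OC1` is the only compound with a finite value, and in this assay compound 2 gives 7490 nM. Within the data shown here, of the values shown, (the limit of > 100000 nM in this assay, at which 1 of the 2 values shown sits), so compound 2 stands alone as the one measured number.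

Compound 3 `C=CC1=C(C(=O)NC2CCCCC2)C(c2ccc(OC)cc2)OC1` remains to be measured. It differs from compound 2 in one place: hydrogen in place of methoxy on an aromatic carbon, ortho to a methoxy group and meta to a large group. Among the measured compounds shown here, no measured pair differs only in this way, so the step has no precedent; compound 1 carries the same single methoxy on that ring but a different amide, and its limit says nothing about this change alone. A modest loss of potency is expected, and the expected step is a 2.0-fold higher number from compound 2 to compound 3 (0.30 log units; within the scatter). For compound 3 the expected value in this assay is 15000 nM, with a range from 5000 nM to 60000 nM.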

Compound 3, half-maximal inhibitory concentration: > 100000 nM
Compound 3 gave a limit, no number; the forecaster's own chance of this, stated with the estimate: 20%; at least 6.6-fold (0.82 log units) between middle value and limit.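

Hydrogen in place of methoxy on this aromatic carbon gives an at least 13-fold higher number from compound 2 to compound 3 (1.12 log units; beyond the scatter) in this assay, the first readable step of the series, so this position is not indifferent to the change. Compound 1 could not show this, since it carries the single methoxy together with a different amide; with the cyclohexyl amide held fixed, the loss of that one methoxy group alone separates a finite value from a limit of the assay. Compound 2 thus remains the only compound with a number, and the step is a lower bound on the true size of the change, with the upper end unknown: the limit of > 100000 nM in this assay, at which 2 of the 3 values shown sit.

On these data alone, the step from compound 1 to compound 3 cannot be read, as both values are limits of the assay, so what the amide contributes with this single-methoxy ring stays open. Also open, as far as these compounds go, is whether this carbon needs methoxy in particular or only some group there: a hydroxyl, a fluorine or an ethoxy group at this place, with the cyclohexyl amide kept, would separate these readings.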